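A few compounds are considered here, and "the series" means these few. Any claim that something is new, unique, unknown or untested is made for them only; others in the source may bear on it.

Compound 1 `CCCc1cc(N)c2cc(NC(=O)/C=C/c3ccc(F)cc3)ccc2n1` gives 200 nM in a functional assay on HEK293 cells for activation of melanin-concentrating hormone receptor 1 (Homo sapiens), read by inositol phosphate accumulation; a higher number here means that more compound is needed for the effect, a lower number that less compound is needed. Compound 2 `CCCc1cc(N)c2cc(NC(=O)/C=C/c3ccc(SC)cc3)ccc2n1` gives 71 nM. Compound 3 `CCCc1cc(N)c2cc(NC(=O)/C=C/c3ccc(CC)cc3)ccc2n1` gives 160 nM.

Among these three numbers compound 3 stands second highest: compound 1 is its nearest neighbour, with a step of a 1.3-fold lower number from compound 1 to compound 3 (0.10 log units; within the scatter), and compound 2 its furthest, with a 2.3-fold higher number from compound 2 to compound 3 (0.35 log units; beyond the scatter). Compound 4 `CCCc1cc(N)c2cc(NC(=O)/C=C/c3ccc(Cl)c(Cl)c3)ccc2n1` has not yet been measured. It differs from compound 3 in one place: 3,4-dichlorophenyl in place of 4-ethylphenyl on a double-bonded chain carbon bound to a double-bonded chain carbon.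

The steps measured so far all swap one group on the same ring carbon: a 2.8-fold lower number from compound 1 to compound 2 (0.45 log units; beyond the scatter), a 1.3-fold lower number from compound 1 to compound 3 (0.10 log units; within the scatter) and a 2.3-fold higher number from compound 2 to compound 3 (0.35 log units; beyond the scatter). None of them introduces a second substituent on that ring, and none involves chlorine, so they bear only loosely on the change from compound 3 to compound 4. They show that exchanges on this ring move this assay by modest amounts at most. Compound 4 is therefore expected to land in the same region, possibly with a modestly lower number, the estimated step being a 1.6-fold lower number from compound 3 to compound 4 (0.20 log units; within the scatter). The estimate for compound 4 is 100 nM, within a range from 40 nM to 300 nM.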

Compound 4, half-maximal effective concentration: 990 nM
Estimate against measurement, compound 4: 9.9-fold (1.00 log units) below, outside the stated range (above it).
By their numbers in this assay, from the lowest: compound 2; then compounds 3 and 1 (each within the scatter of the next); then compound 4.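

In this assay the exchange for 3,4-dichlorophenyl on a double-bonded chain carbon bound to a double-bonded chain carbon gives a 6.2-fold higher number from compound 3 to compound 4 (0.79 log units; beyond the scatter) and a 5.0-fold higher number from compound 1 to compound 4 (0.69 log units; beyond the scatter) as well as a 14-fold higher number from compound 2 to compound 4 (1.14 log units; beyond the scatter) in the same direction. Each of these steps is larger than any exchange among 4-fluorophenyl, 4-(methylsulfanyl)phenyl and 4-ethylphenyl, so this position does not treat all aryl groups alike, and the narrow spread of the first three compounds does not extend to compound 4. Nothing available explains this rise.

The compounds shown leave open whether the higher number goes with having two chlorines or with one of them alone, a question that 4-chlorophenyl would address. They also leave open how an aryl group bearing an amine or a carboxylic acid would read here.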